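Extending the hydroxyalkyl tail of a hydroxycyclohexyl acetic acid

The source may report more compounds than this note shows. Statements on the series, on what has been measured and on what is new or still open speak of the compounds shown alone.

Measured so far:
compound 1, `CCCCCC(O)/C=C/[C@H]1CCC[C@@](O)(CCCC(=O)O)C1`, 70000 nM in an assay on cell membranes for inhibition of leukotriene B4 receptor 1 (Homo sapiens), read by radioligand binding; on this read-out lower numbers stand for stronger inhibition and higher numbers for weaker inhibition
compound 2, `CCCCCC(O)/C=C/[C@H]1CCC[C@@](O)(CC(=O)O)C1`, 8000 nM

Among the measured compounds shown here, compound 2 gives the lowest of the two numbers so far; the one measured step, an 8.8-fold lower number from compound 1 to compound 2 (0.94 log units; beyond the scatter), is the shortening of the acid-bearing chain, and it lies beyond the scatter. Compound 3, `CCCCCCCCC(O)/C=C/[C@H]1CCC[C@@](O)(CC(=O)O)C1`, is not yet measured. It differs from compound 2 by propyl in place of hydrogen on a saturated chain carbon, six bonds along the chain from a double-bonded chain carbon and an oxygen on a saturated carbon, a change at the far end of the hydroxyalkyl chain rather than on the acid side. For the measured compounds named here, no measured step bears on this change, since the only step known concerns the acid chain, so there is no basis for expecting a large shift in either direction. The team expects compound 3 to stay close to compound 2, with a 1.3-fold lower number from compound 2 to compound 3 (0.12 log units; within the scatter) as the estimated step, and the estimate for compound 3 is 6000 nM with a range from 1500 nM to 25000 nM.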

Compound 3, half-maximal inhibitory concentration: 1000 nM
Compound 3: the middle estimate sits 6.0-fold (0.78 log units) above what was measured; measured number outside the range, below it.
By their numbers in this assay, from the lowest: compound 3; then compound 2; then compound 1.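

In this assay, the far end of the hydroxyalkyl chain proves to be a position that responds: propyl in place of hydrogen on a saturated chain carbon, six bonds along the chain from a double-bonded chain carbon and an oxygen on a saturated carbon, gives an 8.0-fold lower number from compound 2 to compound 3 (0.90 log units; beyond the scatter). Until now only the acid-bearing chain had been seen to move the number, so both ends of the molecule are now known to matter, and compound 3 carries the lowest number of the three. No measured evidence here explains the gain. The compounds shown leave open whether a longer chain at this position, or one ending in a phenyl ring, would lower the number further. They also leave open whether the longer tail would give a similar step when paired with the longer acid chain of compound 1.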